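The source may hold more compounds than are shown below. What is called first, only, known or untested is meant among the compounds shown, and "the series" means these compounds.

Series notes. In a functional assay on DU-145 cells (Homo sapiens) for inhibition, read by CCK-8 assay, with a stated time of 72 h (on this read-out higher numbers stand for weaker inhibition and lower numbers for stronger inhibition), compound 1 `O=C(/C=C/c1cccnc1)NCCCCCCc1cccc(S(=O)(=O)Nc2ccccc2)c1` reads 6.73 nM and compound 2 `Cc1ccccc1NS(=O)(=O)c1cccc(CCCCCCNC(=O)/C=C/c2cccnc2)c1` reads 2.9 nM while compound 3 `CC(C)(C)c1ccc(NS(=O)(=O)c2cccc(CCCCCCNC(=O)/C=C/c3cccnc3)c2)cc1` reads 281 nM as the highest number of the three, which makes it the weakest inhibitor measured so far. The next change leads to compound 4 `O=C(/C=C/c1cccnc1)NCCCCCCc1cccc(S(=O)(=O)Nc2ccc(F)c(Cl)c2)c1` and is confined to one group: 3-chloro-4-fluorophenyl in place of 4-(tert-butyl)phenyl on a sulfonamide nitrogen with 3-chloro-4-fluorophenyl in place of 4-(tert-butyl)phenyl on a sulfonamide nitrogen. Going by the values given here, two measured steps bear directly on it. The first is a 42-fold higher number from compound 1 to compound 3 (1.62 log units; beyond the scatter) and is large, with tert-butyl in place of hydrogen on an aromatic carbon. The second is a 97-fold higher number from compound 2 to compound 3 (1.99 log units; beyond the scatter) and is also large. The step of a 2.3-fold lower number from compound 1 to compound 2 (0.37 log units; beyond the scatter) is modest by comparison and runs toward a lower number, with methyl in place of hydrogen. Among the compounds with values here, no compound carrying chlorine or fluorine has been measured, so what those two atoms contribute stays open. Since compound 4 no longer carries the tert-butyl group, its number is expected to return toward compound 1 at 6.73 nM rather than stay at the level of compound 3. The expected change in this assay is a large one toward a lower number, estimated as a 23-fold lower number from compound 3 to compound 4 (1.37 log units; beyond the scatter) in this direction. The estimate for compound 4 is 12 nM with an expected range from 3 nM to 60 nM in this measurement.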

Compound 4, half-maximal inhibitory concentration: 150 nM
Compound 4: the middle estimate sits 13-fold (1.10 log units) below what was measured; measured number above the stated range.
By their numbers in this assay, from the lowest: compound 2; then compound 1; then compounds 4 and 3 (each within the scatter of the next).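

Working notes. In this assay, the step from 4-(tert-butyl)phenyl to 3-chloro-4-fluorophenyl on the sulfonamide nitrogen leaves the two compounds level (a 1.9-fold lower number from compound 3 to compound 4 (0.27 log units; within the scatter)), so the absence of the tert-butyl group is not enough on its own to bring the number back toward the low values of this series. Compound 4 stays far from both low-number compounds, on the phenyl comparison (a 22-fold higher number from compound 1 to compound 4 (1.35 log units; beyond the scatter)) and on the 2-methylphenyl comparison (a 52-fold higher number from compound 2 to compound 4 (1.71 log units; beyond the scatter)), which shows that this position can give a high number with groups as different as tert-butyl and the chlorine and fluorine pair, although compound 2 goes against any rule that a substituent on this ring raises the number. No measurement at hand bears on why these groups read as they do.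

The compounds shown do not separate what chlorine and fluorine each contribute, since they occur only together, so a phenyl carrying chlorine alone or fluorine alone would be the direct test. As far as these compounds go, it also remains open how this position responds to a methoxy group, an amine or a carboxylic acid on the ring, and whether the small methyl of compound 2 is a special case.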